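A Dimethylaminomethylphenyl Group Replaces a Dimethoxypyrimidine

The source may report more compounds than this note shows. Statements on the series, on what has been measured and on what is new or still open speak of the compounds shown alone.

The series is built around a shared core, carried by compound 1 `COc1ncc(C2c3ccccc3C=NN2C(=O)/C=C/c2cc(Cc3cnc(N)nc3N)cc(OC)c2OC)c(OC)n1` and, with variations at the acyl side and the saturated ring carbon, by compound 2 `COc1cc(Cc2cnc(N)nc2N)cc(CCC(=O)N2N=Cc3ccccc3C2C)c1OC` and compound 3 `COc1cc(Cc2cnc(N)nc2N)cc(/C=C/C(=O)N2N=Cc3ccccc3C2c2ccc(CO)cc2)c1O`. In an assay on isolated protein for inhibition of Dihydrofolate reductase (Homo sapiens) (a lower number here means a stronger inhibitor, a higher number a weaker inhibitor), compound 1 gives > 22000 nM, which is a limit of the assay rather than a number. In this assay compound 2 likewise reaches only a limit, > 28000 nM. Compound 3 also stops at a limit in this assay, > 24000 nM. For the measured compounds named here, compound 1 therefore stands among three compounds none of which yields a measured number; the three limits are the limit of > 22000 nM in this assay, at which 1 of the 3 values shown sits, the limit of > 24000 nM in this assay, at which 1 of the 3 values shown sits, and (the limit of > 28000 nM in this assay, at which 1 of the 3 values shown sits), and no step between any two measured compounds can be stated.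

Compound 4 `COc1cc(Cc2cnc(N)nc2N)cc(/C=C/C(=O)N2N=Cc3ccccc3C2c2ccccc2CN(C)C)c1OC` departs from compound 1 by 2-((dimethylamino)methyl)phenyl in place of 2,4-dimethoxypyrimidin-5-yl on a saturated ring carbon. Going by the values given here, with no measured step in this assay to lean on and every neighbour sitting at a limit, no change beyond the scatter is expected in either direction. Compound 4 is therefore estimated at 30000 nM in this assay, within a range from 8000 nM to 100000 nM, and the step from compound 1 to compound 4 is expected to be a step that the limit leaves unreadable from compound 1 to compound 4, most likely again reported only as a limit.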

Compound 4, half-maximal inhibitory concentration: > 42000 nM
Compound 4: a limit, no number; the forecaster's own chance of this, stated with the estimate: 70%; middle value at least 1.4-fold (0.14 log units) away from the limit.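

In this assay compound 4 gives > 42000 nM as a limit and not a number. For the compounds shown here, compound 1 also stands only at a limit, so no step from compound 1 to compound 4 can be read. The compounds shown leave open whether 2-((dimethylamino)methyl)phenyl in place of 2,4-dimethoxypyrimidin-5-yl changes the result in this assay at all.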